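The source may hold more compounds than are shown below. What is called first, only, known or untested is meant among the compounds shown, and "the series" means these compounds.

Of the compounds shown here, three sharing one core have been measured in a functional assay on MCF7 cells (Homo sapiens) for cytotoxicity, read by MTT assay, with a stated time of 48 h; on this read-out lower numbers stand for stronger inhibition and higher numbers for weaker inhibition. Compound 1 `O=C(CSc1nnc(-c2ccncc2)o1)N/N=C/c1ccccc1` gives 14600 nM, compound 2 `O=C(CSc1nnc(-c2ccncc2)o1)N/N=C/c1ccc(Cl)cc1` gives 15300 nM, and compound 3 `O=C(CSc1nnc(-c2ccncc2)o1)N/N=C/c1ccccc1F` gives 21800 nM, the highest of the three numbers, though within the scatter of both others. Compound 4 `O=C(CSc1nnc(-c2ccncc2)o1)N/N=C/c1cc(Br)ccc1O` carries 5-bromo-2-hydroxyphenyl in place of 2-fluorophenyl on a carbon with a double bond to nitrogen. The nearest measured steps each place a single halogen on an aromatic carbon: a 1.5-fold higher number from compound 1 to compound 3 (0.17 log units; within the scatter) and a 1.0-fold higher number from compound 1 to compound 2 (0.02 log units; within the scatter), and the step of a 1.4-fold higher number from compound 2 to compound 3 (0.15 log units; within the scatter) is also within the scatter. Within the data shown here, no measured step covers the added hydroxyl group. On that basis the step of a 1.7-fold lower number from compound 3 to compound 4 (0.22 log units; within the scatter) is expected to stay within the scatter in this assay. Compound 4 is therefore estimated at 13000 nM, in a range from 4000 nM to 40000 nM.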

Compound 4, half-maximal inhibitory concentration: 7770 nM
Estimate against measurement, compound 4: 1.7-fold (0.22 log units) above; the range from low to high includes it.
By their numbers in this assay, from the lowest: compounds 4, 1, 2 and 3 (each within the scatter of the next, the first and the last beyond it).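

In this assay the group on the carbon with a double bond to nitrogen can shift the number beyond the scatter (a 2.8-fold lower number from compound 3 to compound 4 (0.45 log units; beyond the scatter)), the only such step among these compounds. Measured against the other two groups, 5-bromo-2-hydroxyphenyl stays within the scatter (a 2.0-fold lower number from compound 2 to compound 4 (0.29 log units; within the scatter); a 1.9-fold lower number from compound 1 to compound 4 (0.27 log units; within the scatter)), so the separation holds only against 2-fluorophenyl. Nothing measured here offers an explanation for this.

From the compounds shown here alone, the bromine and the hydroxyl arrive together, so their separate shares remain open. Going by these compounds, how an amine or a carboxylic acid on this ring would fare also remains open.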